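Methylamino in place of (1-phenylethyl)amino: working notes

The source may report more compounds than this note shows. Statements on the series, on what has been measured and on what is new or still open speak of the compounds shown alone.

Measured in a functional assay on MDA-MB-435 cells (Homo sapiens) for cytotoxicity, read by MTT assay, with a stated time of 72 h; on this read-out lower numbers stand for stronger inhibition and higher numbers for weaker inhibition:
- compound 1 `C[C@@H](Nc1c(C(=O)NCc2ccc(F)cc2)nc(Br)c2cccnc12)c1ccccc1`: > 20000 nM (a limit)
- compound 2 `C[C@H](Nc1c(C(=O)NCc2ccc(F)cc2)nc(Br)c2cccnc12)c1ccccc1`: > 20000 nM (a limit)

Compound 2 has no number, only a limit, and stands at the limit of > 20000 nM in this assay, at which 2 of the 2 values shown sit. The next structure is compound 3 `CNc1c(C(=O)NCc2ccc(F)cc2)nc(Br)c2cccnc12`, and the change is methyl in place of 1-phenylethyl on a nitrogen on an aromatic ring. In words, methyl takes the place of 1-phenylethyl on a nitrogen on an aromatic ring. Within the data shown here, the only measured step is a step that the two limits leave unreadable from compound 1 to compound 2. Among the measured compounds shown here, it concerns the fact that compounds 1 and 2 differ only in the configuration as drawn and has no readable size, so no measured step shows what this exchange does in this assay. No direction can be drawn from the data, and no step beyond the scatter is expected. This expectation rests on compound 2, which gives > 20000 nM as a limit. The expected change is a number no higher from compound 2 to compound 3 (the limit leaves the size open), an estimate only. For compound 3 the estimated value is 20000 nM, with an expected range of 5000 nM to 40000 nM.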

Compound 3, half-maximal inhibitory concentration: > 20000 nM
Compound 3 ended at the assay's limit; the forecaster's own chance of this, stated with the estimate: 65%; the middle value lies on the limit itself.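

In this assay compound 3 gives > 20000 nM, a limit and not a number. No new step can be read between compound 3 and either compound 1 or compound 2. The compounds shown leave open what methyl in place of 1-phenylethyl does to the read-out.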